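Adding an Amino Group to Compound 2

The source may report more compounds than this note shows. Statements on the series, on what has been measured and on what is new or still open speak of the compounds shown alone.

Measured in a functional assay on KB cells (Homo sapiens) for antiproliferative activity, read by MTT assay, with a stated time of 72 h; a lower number here means a stronger inhibitor, a higher number a weaker inhibitor:
- Compound 1 (`COc1ccc(-c2ssc(=S)c2-c2cc(OC)c(OC)c(OC)c2)cc1[N+](=O)[O-]`): > 100000 nM (a limit)
- Compound 2 (`COc1ccc(-c2ssc(=O)c2-c2cc(OC)c(OC)c(OC)c2)cc1`): 324 nM

Among the measured compounds shown here, compound 2 holds the only true number so far, 324 nM in this assay, so there is no series to rank it against. Compound 1 reached only a limit, > 100000 nM, and not a number.

The next compound is compound 3 (`COc1ccc(-c2ssc(=O)c2-c2cc(OC)c(OC)c(OC)c2)cc1N`). The change is amino in place of hydrogen on an aromatic carbon, turning 4-methoxyphenyl into 3-amino-4-methoxyphenyl. For the measured compounds named here, no measured pair shows this change alone, so what follows is a judgement and not a trend. In this assay, the expected move is a 5.4-fold lower number from compound 2 to compound 3 (0.73 log units; beyond the scatter), toward stronger inhibition and beyond the usual scatter, though with wide uncertainty. Compound 3 is estimated at 60 nM, with an expected range from 6 nM to 450 nM.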

Compound 3, half-maximal inhibitory concentration: 60 nM
For compound 3 middle estimate and measured number coincide at the digits printed; measured number inside the range.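

In this assay, putting amino in place of hydrogen on the aromatic carbon ortho to the methoxy group gives a 5.4-fold lower number from compound 2 to compound 3 (0.73 log units; beyond the scatter), a move toward stronger inhibition. Among the compounds shown here, this is the first direct reading of this position: it can carry a substituent, and a single added nitrogen is enough to shift activity beyond the usual scatter. For the compounds shown here, compound 1 also carries a group at this position, a nitro group, but it differs from compound 3 in a second place as well, with sulfur in place of the carbonyl oxygen, so no step to it can be read.

The compounds shown do not tell whether a hydroxyl group, a methylamino group or an acetamide at this position would match the amino group. Nothing measured here gives a reason for the step.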